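The compounds below may be only part of what the source reports. "The series", "measured", "known", "first", "only" and "open" are said of these compounds alone.

Measured so far in a functional assay with Rattus norvegicus as the target; on this read-out lower numbers stand for an effect already at smaller amounts and higher numbers for an effect only at larger amounts of compound: compound 1 `CC1(C)C=C(n2ccccc2=O)c2cc(S(=O)(=O)N=[N+]=[N-])ccc2O1` gives 16.2 nM; compound 2 `CC1(C)C=C(n2ccccc2=O)c2cc(S(N)(=O)=O)ccc2O1` gives 69.2 nM; compound 3 `CNS(=O)(=O)c1ccc2c(c1)C(n1ccccc1=O)=CC(C)(C)O2` gives 17.8 nM.

Compound 3 sits second of three numbers, alongside compound 1, since a 1.1-fold higher number from compound 1 to compound 3 (0.04 log units; within the scatter); only compound 2 stands apart, with a 3.9-fold lower number from compound 2 to compound 3 (0.59 log units; beyond the scatter). Compound 4 `COc1ccc(NS(=O)(=O)c2ccc3c(c2)C(n2ccccc2=O)=CC(C)(C)O3)cc1` differs from compound 3 by 4-methoxyphenyl in place of methyl on a sulfonamide nitrogen. For the measured compounds named here, the one step that bears on this position is the substituent change on the sulfonamide nitrogen, a 3.9-fold lower number from compound 2 to compound 3 (0.59 log units; beyond the scatter), a modest step; no measured step covers an aryl group there, so the direction for a larger group is not settled. A modest step in either direction, or none beyond the scatter, is expected, estimated as a 1.7-fold higher number from compound 3 to compound 4 (0.23 log units; within the scatter). Compound 4 is expected at 30 nM, within 8 nM to 120 nM.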

Compound 4, half-maximal effective concentration: 117 nM
The estimate for compound 4 lay 3.9-fold (0.59 log units) below the measured number, and the stated range covers the measured number.
By their numbers in this assay, from the lowest: compounds 1 and 3 (each within the scatter of the next); then compounds 2 and 4 (each within the scatter of the next).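

On the sulfonamide nitrogen, methyl and 4-methoxyphenyl are not interchangeable: the aryl group gives the first upward step from the methyl level (a 6.6-fold higher number from compound 3 to compound 4 (0.82 log units; beyond the scatter)) and also separates clearly from the azido compound (a 7.2-fold higher number from compound 1 to compound 4 (0.86 log units; beyond the scatter)). Hydrogen and 4-methoxyphenyl on that nitrogen cannot be told apart (a 1.7-fold higher number from compound 2 to compound 4 (0.23 log units; within the scatter)), so a small and a large group read alike here, with methyl apart from both. No evidence in hand accounts for this.

Still open, on these data alone, is whether the aryl ring or its methoxy carries the step. Plain phenyl, or ethyl and longer alkyl chains on that nitrogen, would address this.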